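An Acetamidophenyl Variant in an Inactive Triazole Series

This account rests on a few compounds, and the source may have more. Where it says the series, first, only, none or still open, it means among the compounds named here.

Compound 3, `CCOc1ccccc1-n1nncc1CN1C(=O)C2(C(C#N)=C(N)Oc3c2c2nc4ccccc4nc2c2ccccc32)c2ccccc21`, is one of three close relatives tested in a functional assay on MCF7 cells (Homo sapiens) for antiproliferative activity, read by MTT assay, with a stated time of 48 h; on this read-out lower numbers stand for stronger inhibition and higher numbers for weaker inhibition. In that assay compound 3 gives only a limit, > 50000 nM. Compound 1, `Cc1cccc(-n2nncc2CN2C(=O)C3(C(C#N)=C(N)Oc4c3c3nc5ccccc5nc3c3ccccc43)c3ccccc32)c1`, likewise reaches only a limit in this assay, > 50000 nM. Compound 2, `COc1ccc(-n2nncc2CN2C(=O)C3(C(C#N)=C(N)Oc4c3c3nc5ccccc5nc3c3ccccc43)c3ccccc32)cc1`, also gives no number in this assay and stays at the limit > 50000 nM. The three steps among these compounds, a step that the two limits leave unreadable from compound 1 to compound 2, a step that the two limits leave unreadable from compound 1 to compound 3 and a step that the two limits leave unreadable from compound 2 to compound 3, therefore cannot be read, since every one of the values sits at the limit of > 50000 nM in this assay, at which 3 of the 3 values shown sit.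

Compound 4, `CC(=O)Nc1ccc(-n2nncc2CN2C(=O)C3(C(C#N)=C(N)Oc4c3c3nc5ccccc5nc3c3ccccc43)c3ccccc32)cc1`, has not yet been measured. Its change from compound 3 is 4-acetamidophenyl in place of 2-ethoxyphenyl on an aromatic nitrogen. For the measured compounds named here, the measured steps that exchange one aryl group on the same aromatic nitrogen all end at the limit, so none of them yields a size or a direction for this new exchange, and nothing among the measured compounds shows an aryl exchange bringing the potency into the readable range. Compound 4 is therefore expected to remain at or close to the limit as well, with a step that the limit leaves unreadable from compound 3 to compound 4 as the expected step. The estimate for compound 4 in this assay is 60000 nM, with a range from 20000 nM to 200000 nM.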

Compound 4, half-maximal inhibitory concentration: > 50000 nM
Compound 4 was reported as a limit (the forecaster's own chance of this, stated with the estimate: 85%); the middle value does not contradict the limit.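

In this assay compound 4 gives > 50000 nM as a limit, not a number. Its steps from compound 1, compound 2 and compound 3 therefore cannot be read: the limit of > 50000 nM in this assay, at which 4 of the 4 values shown sit. The compounds shown leave open whether any aryl exchange on this aromatic nitrogen can bring the shared core into the readable range.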